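A few compounds are considered here, and "the series" means these few. Any claim that something is new, unique, unknown or untested is made for them only; others in the source may bear on it.

Three compounds share one core and differ only in the aryl group on the benzylic ether. In a functional assay on HT-29 cells (Homo sapiens) for inhibition, read by MTT assay, with a stated time of 48 h (on this read-out lower numbers stand for stronger inhibition and higher numbers for weaker inhibition), compound 1, `Cc1ccc(NC(=S)NC(=O)c2ccc(OCc3ccccc3F)cc2)cc1-c1nc2ccccc2[nH]1`, gives 1870 nM. Compound 2, `Cc1ccc(NC(=S)NC(=O)c2ccc(OCc3cccc(F)c3)cc2)cc1-c1nc2ccccc2[nH]1`, gives 55300 nM in this assay, and compound 3, `Cc1ccc(NC(=S)NC(=O)c2ccc(OCc3ccc(Cl)cc3Cl)cc2)cc1-c1nc2ccccc2[nH]1`, gives 11600 nM in this assay. Within this set compound 3 holds the second-highest number: the step of a 4.8-fold lower number from compound 2 to compound 3 (0.68 log units; beyond the scatter) separates it from the nearer compound 2, and the step of a 6.2-fold higher number from compound 1 to compound 3 (0.79 log units; beyond the scatter) from the farther compound 1. The other measured step, a 30-fold higher number from compound 1 to compound 2 (1.47 log units; beyond the scatter), also concerns only the benzylic aryl group.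

Compound 4, `O=C(NC(=S)Nc1ccc(Cl)c(-c2nc3ccccc3[nH]2)c1)c1ccc(OCc2ccc(Cl)cc2Cl)cc1`, keeps the dichlorinated benzylic aryl group of compound 3 and changes a different part of the molecule: chloro in place of methyl on an aromatic carbon. Among the measured compounds shown here, no measured step touches that position; all three steps move the substituent on the benzylic ring and leave the methyl untouched, so none of them bears directly on this exchange. Without a comparable step there is no ground for expecting a shift in either direction beyond the scatter, and the estimate must stay wide. The step expected in this assay is therefore a 1.0-fold higher number from compound 3 to compound 4 (0.01 log units; within the scatter), essentially none. Compound 4 is accordingly estimated at 12000 nM, with a range from 4000 nM to 40000 nM.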

Compound 4, half-maximal inhibitory concentration: 6080 nM
Compound 4: middle estimate off by 2.0-fold (0.30 log units), on the high side; measured number inside the range.
By their numbers in this assay, from the lowest: compound 1; then compounds 4 and 3 (each within the scatter of the next); then compound 2.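

In this assay, among the compounds shown here, the exchange of methyl for chloro on the aromatic carbon ortho to a 1H-benzimidazol-2-yl group and para to a large group gives a 1.9-fold lower number from compound 3 to compound 4 (0.28 log units; within the scatter), so this position, which no earlier step had touched, tolerates the change without a shift beyond the scatter, at least with the 2,4-dichlorophenyl group in place. For the compounds shown here, the contrast lies with the benzylic aryl group, where a single change can give a step as large as a 30-fold higher number from compound 1 to compound 2 (1.47 log units; beyond the scatter); in this small set, the one exchange at the methyl position is much less consequential than that step, though one exchange on one background cannot define the position as a whole. The data offer no explanation for why this exchange leaves the number within the scatter.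

The compounds shown leave open whether chloro in place of methyl would also stay within the scatter alongside the 2-fluorophenyl group of compound 1 or the 3-fluorophenyl group of compound 2. They also leave open how this position would respond to a group of another kind, such as an amine, a carboxylic acid or a longer alkyl chain.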